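The source may report more compounds than this note shows. Statements on the series, on what has been measured and on what is new or still open speak of the compounds shown alone.

Compound 1 `CCCN(c1ncc(C)c(-c2ccc(OC)cc2OC)n1)C(C1CC1)C1CC1` and compound 2 `CCCN(c1ncc(C)c(-c2c(C)cc(OC)cc2OC)n1)C(C1CC1)C1CC1` share one core. In an assay on CHO cells for displacement of a labelled ligand from corticotropin-releasing factor receptor 1 (Homo sapiens) (a lower number here means a stronger inhibitor, a higher number a weaker inhibitor), compound 1 gives 19 nM, and compound 2 gives 15 nM. The change between them is methyl in place of hydrogen on an aromatic carbon, and the step it made is a 1.3-fold lower number from compound 1 to compound 2 (0.10 log units; within the scatter). Compound 3 `CCCN(c1ncc(C)c(-c2ccc(Br)cc2)n1)C(C1CC1)C1CC1` carries a different core; the difference between the two cores is not broken down here. In this assay compound 3 gives 49 nM, the highest of the three measured numbers. Compound 4 `CCCN(c1ncc(C)c(-c2ccc(Br)cc2C)n1)C(C1CC1)C1CC1` has not yet been measured. Relative to compound 3 it carries methyl in place of hydrogen on an aromatic carbon, the same kind of change as that from compound 1 to compound 2, though the surroundings differ: in compound 2 the new methyl sits meta to two methoxy groups, whereas in compound 4 it sits meta to a bromo group. Because a 1.3-fold lower number from compound 1 to compound 2 (0.10 log units; within the scatter) stayed within the scatter, a similarly small step is expected here, a 1.2-fold lower number from compound 3 to compound 4 (0.09 log units; within the scatter). For compound 4 in this assay the estimate is 40 nM, most likely between 15 nM and 110 nM.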

Compound 4, inhibition constant: 63 nM
For compound 4 the middle estimate is 1.6-fold (0.20 log units) below the measured one; the range from low to high includes it.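

In this assay, for the compounds shown here, methyl in place of hydrogen on an aromatic carbon gave a 1.3-fold higher number from compound 3 to compound 4 (0.11 log units; within the scatter), so on the core of compound 3, as on the core of compound 1, the change made no step that can be read. This does not show that the two steps truly point in opposite directions, and it does not show that the change would stay this small on any other core in the series. What the pair does show is limited to these two cores, where the steps cannot be told apart and the change carries over as a step too small to read: the same change on two cores in this assay, a 1.3-fold lower number (0.10 log units; within the scatter) from compound 1 to compound 2 and a 1.3-fold higher number (0.11 log units; within the scatter) from compound 3 to compound 4, 1.6-fold (0.21 log units) apart, within the scatter of two such steps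

The compounds shown leave open whether a group other than methyl on that same aromatic carbon, such as ethyl, chlorine or an amine, would give a step beyond the scatter on either core. They also leave open whether a carboxylic acid or a longer chain there would do the same.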